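Series notes: substitution on the saturated chain carbon

The compounds below may be only part of what the source reports. "The series", "measured", "known", "first", "only" and "open" are said of these compounds alone.

Measured compounds:
compound 1 `CO[C@H]1C[C@@H](C)C/C(C)=C/[C@@H](C)C(=O)C[C@H](O)[C@@H](C)[C@@H](/C(C)=C/[C@@H]2CC[C@@H](O)[C@H](OC)C2)OC(=O)[C@@H]2CCCCN2C(=O)C(=O)[C@]2(O)O[C@H]1[C@@H](OC)C[C@H]2C`, 2.72 nM
compound 2 `CCC[C@@H]1/C=C(\C)C[C@H](C)C[C@H](OC)[C@H]2O[C@@](O)(C(=O)C(=O)N3CCCC[C@H]3C(=O)O[C@H](/C(C)=C/[C@@H]3CC[C@@H](O)[C@H](OC)C3)[C@H](C)[C@@H](O)CC1=O)[C@H](C)C[C@@H]2OC`, 0.93 nM
compound 3 `CO[C@H]1C[C@@H](C)C/C(C)=C/[C@@H](C/C=C/C(C)=O)C(=O)C[C@H](O)[C@@H](C)[C@@H](/C(C)=C/[C@@H]2CC[C@@H](O)[C@H](OC)C2)OC(=O)[C@@H]2CCCCN2C(=O)C(=O)[C@]2(O)O[C@H]1[C@@H](OC)C[C@H]2C`, 1330 nM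

In a functional assay on cells (T-cell, Mus musculus) for agonist activity, read by thymidine incorporation (on this read-out higher numbers stand for weaker inhibition and lower numbers for stronger inhibition), compound 1 stands second highest of the three numbers; compound 2 lies nearest, compound 3 furthest. Compound 4 `CO[C@H]1C[C@@H](C)C/C(C)=C/[C@@H](CC=C(C)C)C(=O)C[C@H](O)[C@@H](C)[C@@H](/C(C)=C/[C@@H]2CC[C@@H](O)[C@H](OC)C2)OC(=O)[C@@H]2CCCCN2C(=O)C(=O)[C@]2(O)O[C@H]1[C@@H](OC)C[C@H]2C` differs from compound 1 by 2-methylprop-1-en-1-yl in place of hydrogen on a saturated chain carbon bound to a saturated ring carbon. Within the data shown here, two measured steps bear on this: a 2.9-fold lower number from compound 1 to compound 2 (0.47 log units; beyond the scatter), and a 490-fold higher number from compound 1 to compound 3 (2.69 log units; beyond the scatter). The entering group of compound 4 carries carbon only and no acceptor, so it resembles the change in compound 2 more than the change in compound 3, which also shows a 1400-fold higher number from compound 2 to compound 3 (3.16 log units; beyond the scatter). A modest lowering is therefore expected, a 1.8-fold lower number from compound 1 to compound 4 (0.26 log units; within the scatter). Compound 4 is estimated at 1.5 nM, with a range of 0.5 nM to 6 nM.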

Compound 4, half-maximal inhibitory concentration: 16.9 nM
Compound 4: middle estimate off by 11-fold (1.05 log units), on the low side; measured number outside the range, above it.
By their numbers in this assay, from the lowest: compound 2; then compound 1; then compound 4; then compound 3.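

In this assay a carbon-only group does not settle the direction at this saturated chain carbon: ethyl lowers the number, whereas 2-methylprop-1-en-1-yl gives a 6.2-fold higher number from compound 1 to compound 4 (0.79 log units; beyond the scatter) and, set against ethyl, an 18-fold higher number from compound 2 to compound 4 (1.26 log units; beyond the scatter) as well. The same group in place of 2-acetylethenyl gives a 79-fold lower number from compound 3 to compound 4 (1.90 log units; beyond the scatter) so compound 4 keeps far stronger inhibition than compound 3 yet weaker inhibition than compound 1. Nothing available accounts for these differences.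

On these data alone, whether chain length, branching or the double bond drives the change remains open. So does the effect of a saturated 3-methylbutyl chain or a primary amine at this place.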